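Swapping the Amide Substituent on a Shared Core

The source may hold more compounds than are shown below. What is called first, only, known or untested is meant among the compounds shown, and "the series" means these compounds.

Three measured compounds share one core and differ only in the group bound to the amide carbonyl. Compound 1 `CCN(CC)C(=O)CC1CCc2cc(OC)c(OC)cc21` carries a diethylamino group, compound 2 `CCCNC(=O)CC1CCc2cc(OC)c(OC)cc21` a propylamino group, and compound 3 `COc1cc2c(cc1OC)C(CC(=O)NC1CCCCC1)CC2` a cyclohexylamino group. In a functional assay on the whole organism (strain Wistar) for inhibition, with Rattus norvegicus as the target, read by paw edema, with stated times of 60 min and 6 h, at a dose of 100 mg/kg by the oral route (on this read-out lower numbers stand for less inhibition and higher numbers for more inhibition at the one dose given (going by the name of the read-out)), compound 1 gives 31.5%, compound 2 gives 22.2%, and compound 3 gives 48.2%. Compound 3 stands highest of the three, since a number 16.7 percentage points higher from compound 1 to compound 3 (beyond the scatter) and a number 26 percentage points higher from compound 2 to compound 3 (beyond the scatter) both lie beyond the scatter, whereas a number 9.3 percentage points lower from compound 1 to compound 2 (within the scatter) does not. Compound 4 `COc1cc2c(cc1OC)C(CC(=O)N1CCNCC1)CC2` has not been measured; it differs from compound 3 in one place: piperazin-1-yl in place of cyclohexylamino on a carbonyl carbon. Among the compounds with values here, no measured step exchanges one ring for another at this position, but all three measured steps concern the group on the carbonyl carbon and shifted the read-out by modest amounts at most, so a step of similar size, more likely downward than upward, is expected here. Compound 4 is therefore estimated to give 32%, with a range from 15% to 50%. The expected step is a number 16.2 percentage points lower from compound 3 to compound 4 (beyond the scatter).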

Compound 4, a percentage reported as inhibition, in the whole organism at one dose (the size of the read-out at that dose, not a potency): 33.3%
For compound 4 the middle estimate is 1.3 percentage points below the measured one; the range from low to high includes it.
By their numbers in this assay, from the lowest: compounds 2, 1 and 4 (each within the scatter of the next, the first and the last beyond it); then compound 3.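

Compound 4 puts a ring with 2 hetero atoms on the carbonyl carbon, and in this assay this shows that the high number of compound 3 does not carry over to every six-membered non-aromatic ring here, with a number 14.9 percentage points lower from compound 3 to compound 4 (beyond the scatter). The piperazin-1-yl group still reads beyond the scatter above the propylamino group, with a number 11.1 percentage points higher from compound 2 to compound 4 (beyond the scatter), yet it cannot be told apart from the diethylamino group, with a number 1.8 percentage points higher from compound 1 to compound 4 (within the scatter). Nothing measured here accounts for these differences.

Still open, as far as these compounds go, is how a piperidin-1-yl group, with carbon in place of the second ring nitrogen, or a morpholin-4-yl group, with oxygen there, would read on the same carbonyl carbon. A 4-methylpiperazin-1-yl group would also test whether the free ring nitrogen of compound 4 matters.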